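Small sulfur swap, small expected shift

The compounds below may be only part of what the source reports. "The series", "measured", "known", "first", "only" and "open" are said of these compounds alone.

Measured so far in a functional assay on DU-145 cells (Homo sapiens) for inhibition, read by trypan blue exclusion, with a stated time of 96 h (on this read-out lower numbers stand for stronger inhibition of growth and higher numbers for weaker inhibition of growth), with these results
- compound 1 `O=C(/C(=C\c1ccccc1OCc1ccccc1)SCc1ccc(Cl)c(Cl)c1)c1ccc(Cl)cc1` gives 10000 nM
- compound 2 `COc1ccc(S/C(=C/c2ccccc2OCc2ccccc2)C(=O)c2ccc(Cl)cc2)cc1` gives 1000 nM
- compound 3 `O=C(/C(=C\c1ccccc1OCc1ccccc1)Sc1ccc(Br)cc1)c1ccc(Cl)cc1` gives 10000 nM

Compound 1 is level with compound 3 (10000 nM), and together they hold the highest of the three numbers. The next compound, compound 4 `Cc1ccc(CS/C(=C/c2ccccc2OCc2ccccc2)C(=O)c2ccc(Cl)cc2)cc1`, carries 4-methylbenzyl in place of 4-bromophenyl on a sulfur.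

The nearest guide is another exchange on that sulfur, one that also ends in 4-bromophenyl. It gave no change at the digits printed from compound 1 to compound 3 (within the scatter) and so stayed within the scatter. The larger movement in this small set, a 10-fold higher number from compound 2 to compound 3 (1.00 log units; beyond the scatter), is a modest step, but it is an exchange of methoxy and bromo, and compound 4 has no methoxy. Among the measured compounds shown here, with only three measured compounds, this guidance is thin.

At most a slight shift in this assay is therefore expected, with no step beyond the scatter. The expected change is a 1.7-fold lower number from compound 3 to compound 4 (0.22 log units; within the scatter) on this estimate. For compound 4 the estimated value is 6000 nM with an expected range from 1500 nM to 15000 nM when it is measured.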

Compound 4, concentration for 50% growth inhibition: 1000 nM
Compound 4: middle estimate off by 6.0-fold (0.78 log units), on the high side; the whole stated range lies above it.
By their numbers in this assay, from the lowest: compounds 2 and 4 (each within the scatter of the next); then compounds 1 and 3 (each within the scatter of the next).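

The step of a 10-fold lower number from compound 3 to compound 4 (1.00 log units; beyond the scatter) shows that an exchange on this sulfur can move the number beyond the scatter, which the earlier exchange of 3,4-dichlorobenzyl for 4-bromophenyl did not show. A benzyl group does not set the level alone, since the change of ring substituents in a 10-fold lower number from compound 1 to compound 4 (1.00 log units; beyond the scatter) separates two benzyl compounds, while no change at the digits printed from compound 2 to compound 4 (within the scatter) places 4-methylbenzyl level with 4-methoxyphenyl. Across these four compounds, the sulfur groups carrying chloro or bromo give the higher numbers and those carrying methyl or methoxy give the lower numbers, with no compound going against this split.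

No measurement shown gives a reason for the split. From the compounds shown here alone, whether it holds for a sulfur group carrying an amine or a carboxylic acid, or for a longer chain on the sulfur, remains open.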